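A Chloro Step Repeated on a Phenoxy-Bearing Core

The compounds below may be only part of what the source reports. "The series", "measured", "known", "first", "only" and "open" are said of these compounds alone.

Compound 1 `Nc1nc(NCc2ccccc2)nc(-c2ccccc2CO)n1` is the starting point. In a functional assay on cells for positive allosteric modulation of G-protein coupled receptor 68 (Homo sapiens), read by a luciferase reporter and cAMP accumulation, with a stated time of 30 min, at pH 6.8 and pH 8.3, in the presence of a further agent that is not named here (a higher number here means a more potent compound, by a factor of ten per unit of this negative logarithm, a lower number a less potent compound), compound 1 gives 4.35. Compound 2 `Nc1nc(NCc2ccccc2)nc(-c2c(Cl)cccc2CO)n1` differs from it in a single place: chloro in place of hydrogen on an aromatic carbon. In this assay compound 2 gives 4.43, so the step of a number 0.08 log units higher from compound 1 to compound 2 (within the scatter). Compound 3 `Nc1nc(NCc2ccc(Oc3ccccc3)cc2)nc(-c2ccccc2CO)n1` carries a different change, and its core differs from the core of compound 1 by phenoxy in place of hydrogen on an aromatic carbon. In this assay compound 3 gives 5.19, the step of a number 0.84 log units higher from compound 1 to compound 3 (beyond the scatter), and compound 3 stands highest of the three measured compounds.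

Compound 4 `Nc1nc(NCc2ccc(Oc3ccccc3)cc2)nc(-c2cc(Cl)ccc2CO)n1` has not yet been measured. It differs from compound 3 by the same kind of change that separates compound 1 from compound 2: chloro in place of hydrogen on an aromatic carbon. The place is not identical: in compound 2 the chloro sits ortho to a large group and meta to the hydroxymethyl group, whereas in compound 4 it sits meta to a large group and para to the hydroxymethyl group. Because the earlier step of a number 0.08 log units higher from compound 1 to compound 2 (within the scatter) was small, a small step of a number 0.06 log units higher from compound 3 to compound 4 (within the scatter) is expected here too, with some extra uncertainty from the changed place. Compound 4 is therefore estimated at 5.25, likely between 4.85 and 5.65.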

Compound 4, negative logarithm of the antagonist equilibrium constant: 4.7
Estimate against measurement, compound 4: 0.55 log units above; the measured number lies below the stated range.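

On the phenoxy-bearing core, the chloro step comes out as a number 0.49 log units lower from compound 3 to compound 4 (beyond the scatter). Set beside the earlier step, this shows that in this assay the same change does not carry over unchanged between these two cores: the same change on two cores in this assay, a number 0.08 log units higher (within the scatter) from compound 1 to compound 2 and a number 0.49 log units lower (beyond the scatter) from compound 3 to compound 4, 0.57 log units apart, beyond the scatter of two such steps It does not show why, since the chloro sits meta to a large group and para to a hydroxymethyl group in compound 4 but elsewhere on the ring in compound 2, so the core and the place changed together and these two steps cannot tell them apart.

The compounds shown leave open what chloro would do at the place it has in compound 4 on the core of compound 1, or at the place it has in compound 2 on the core of compound 3. They also leave open whether a fluoro or a methyl group, put para to the hydroxymethyl group on the phenoxy-bearing core, would lower the number as chloro does.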